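A few compounds are considered here, and "the series" means these few. Any claim that something is new, unique, unknown or untested is made for them only; others in the source may bear on it.

Compound 1 `CC1=C(C(=O)OC(C)(C)C)C(c2cccs2)NC(=O)N1` and compound 2 `CC1=C(C(=O)OCc2ccccc2)C(c2cccs2)NC(=O)N1` are built on the same core and differ in one spot only: benzyl in place of tert-butyl on an oxygen next to a carbonyl group. In an assay on membranes from CHO cells for displacement of a labelled ligand from adenosine receptor A1 (Homo sapiens), read by scintillation counting, with a stated time of 60 min, tested at 1 uM (on this read-out lower numbers stand for less inhibition and higher numbers for more inhibition at the one concentration tested (going by the name of the read-out)), compound 1 gives 26%, and in this assay compound 2 gives 45%. The change made a number 19 percentage points higher from compound 1 to compound 2 (beyond the scatter). Compound 3 `CC1=C(C(=O)OC(C)(C)C)C(c2ccsc2)NC(=S)N1` is built on another core; the difference between the two cores is not broken down here. In this assay compound 3 gives 16%. Set against compound 1, the value of compound 3 lies within the scatter; set against compound 2, it lies beyond it.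

Compound 4 `CC1=C(C(=O)OCc2ccccc2)C(c2ccsc2)NC(=S)N1` has not yet been measured. It stands to compound 3 as compound 2 stands to compound 1: benzyl in place of tert-butyl on an oxygen next to a carbonyl group. The place of the change is described in the same words for both pairs, so it is the same change, only carried out on the core of compound 3. Among the compounds with values here, the single measured instance of this change is the step from compound 1 to compound 2, and because that step was a number 19 percentage points higher from compound 1 to compound 2 (beyond the scatter), a step of about the same size is expected here, namely a number 19 percentage points higher from compound 3 to compound 4 (beyond the scatter). Since the expectation rests on one pair alone, and on a different core, it is held with wide margins. Compound 4 is therefore estimated at 35% in this assay, expected to fall between 20% and 50%.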

Compound 4, a percentage reported as inhibition, at one concentration (the size of the read-out at that concentration, not a potency): 3%
Beside the measured number, compound 4's estimate is 32 percentage points above it; the measured number lies below the stated range.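

On the core of compound 3, putting benzyl in place of tert-butyl on the oxygen next to the carbonyl group gave, in this assay, a step that was a number 13 percentage points lower from compound 3 to compound 4 (beyond the scatter). Set beside the earlier result, the same swap moved the number in opposite directions on the two cores: the same change on two cores in this assay, a number 19 percentage points higher (beyond the scatter) from compound 1 to compound 2 and a number 13 percentage points lower (beyond the scatter) from compound 3 to compound 4, 32 percentage points apart, beyond the scatter of two such steps. This shows that, for these two pairs, the step seen on one core could not simply be carried over to the other, but it does not show why the direction changed, and with a single pair on each core it gives no general rule for the series; the read-out is also the size of the inhibition at one concentration, not a potency.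

The compounds shown leave open which of the differences between the core of compound 1 and the core of compound 3 goes with the change in direction, since no pair here separates those differences. They also leave open how other groups on that oxygen, such as a straight propyl chain or a longer phenylethyl chain, would behave on either core.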